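This account rests on a few compounds, and the source may have more. Where it says the series, first, only, none or still open, it means among the compounds named here.

Compound 3 `Cc1cc(O)c(C(C)C)cc1-c1cc(-c2cccs2)c(C#N)c(=O)[nH]1` was tested in a functional assay for inhibition, tested at 20 ug/mL (on this read-out lower numbers stand for a weaker effect and higher numbers for a stronger effect at the one concentration tested), where compound 3 gives 26%. Two measured companions share its core. Compound 1 `Cc1cc(O)c(C(C)C)cc1-c1cc(-c2ccccc2[N+](=O)[O-])c(C#N)c(=O)[nH]1` carries 2-nitrophenyl where compound 3 carries thiophen-2-yl; in this assay compound 1 gives 20%. Compound 2 `COc1cc(OC)c(-c2cc(-c3cc(C(C)C)c(O)cc3C)[nH]c(=O)c2C#N)c(OC)c1`, which carries a methoxy-bearing phenyl group at that same place, gives 32%. Compound 3 therefore sits within the scatter of both neighbours: the exchange gave a number 6 percentage points higher from compound 1 to compound 3 (within the scatter), and the gap between compound 3 and compound 2 also falls within the scatter.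

Among the measured compounds shown here, compound 4 `COc1ccc(-c2cc(-c3cc(C(C)C)c(O)cc3C)[nH]c(=O)c2C#N)cc1OC` is the compound to be measured next. 3,4-dimethoxyphenyl in place of thiophen-2-yl on an aromatic carbon Only one measured step touches this place on the core, the one from compound 1 to compound 3, and it stayed within the scatter. Compound 2, with its own methoxy-bearing phenyl at the same place, gives a number within the scatter of compound 3. Neither observation points beyond the scatter, so the step expected in this assay is a number 4 percentage points higher from compound 3 to compound 4 (within the scatter), none beyond the scatter. Compound 4 is estimated at 30%, with a range from 18% to 42%.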

Compound 4, a percentage reported as inhibition, at one concentration (the size of the read-out at that concentration, not a potency): 25%
Compound 4: the middle estimate sits 5 percentage points above what was measured; the range from low to high includes it.
By their numbers in this assay, from the lowest: compounds 1, 4, 3 and 2 (each within the scatter of the next, the first and the last beyond it).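

In this assay, putting 3,4-dimethoxyphenyl, with 10 heavy atoms, in place of thiophen-2-yl, with 5, gives a number 1 percentage points lower from compound 3 to compound 4 (within the scatter) and putting it in place of 2-nitrophenyl gives a number 5 percentage points higher from compound 1 to compound 4 (within the scatter) at this same place on the shared core. The place opposite the ring nitrogen therefore takes a five-membered ring and two differently substituted six-membered rings with no step beyond the scatter among compound 1, compound 3 and compound 4, although compound 2, the other methoxy-bearing compound, lies beyond the scatter of compound 1. No measurement shown explains why these groups read so alike.

Still open, going by these compounds, is whether an amine, a carboxylic acid or a longer chain at this place would move the number beyond the scatter. Also open, on these data alone, is how these compounds rank in potency, which a read-out at one concentration does not give.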